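A few compounds are considered here, and "the series" means these few. Any claim that something is new, unique, unknown or untested is made for them only; others in the source may bear on it.

Compound 1 `CC(C)(C)c1ccc(-c2ccc3c(NCCCNCc4ccco4)ccnc3c2)cc1` and compound 2 `CCC(CC)c1ccc2c(NCCCNCc3ccco3)ccnc2c1` share one core and differ in a single group. Going by the values given here, in a physicochemical assay for solubility, with a stated time of 18 h, at pH 7.4 (on this read-out lower numbers stand for lower solubility and higher numbers for higher solubility), compound 1 gives 32000 nM, and compound 2 gives 4200 nM, the lower of the two numbers measured so far. Among the compounds with values here, the only measured step, a 7.6-fold lower number from compound 1 to compound 2 (0.88 log units; beyond the scatter), swapped an aromatic group for a branched chain. Compound 3 `COc1ccc(-c2ccc3c(NCCCNCc4ccco4)ccnc3c2)cc1` now takes the step from compound 2 in which (4-methoxyphenyl in place of pentan-3-yl on an aromatic carbon). Since this largely reverses the earlier change, a rise in this assay of roughly that size is expected, giving an estimated step of a 9.5-fold higher number from compound 2 to compound 3 (0.98 log units; beyond the scatter). For compound 3 the expected value is 40000 nM, within 12000 nM to 130000 nM.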

Compound 3, solubility: 32000 nM
Estimate against measurement, compound 3: 1.3-fold (0.10 log units) above, within the range that was stated.
By their numbers in this assay, from the lowest: compound 2; then compounds 1 and 3 (each within the scatter of the next).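

In this assay the step of a 7.6-fold higher number from compound 2 to compound 3 (0.88 log units; beyond the scatter) shows that the higher number at this position is not unique to 4-(tert-butyl)phenyl, since 4-methoxyphenyl, another group with a six-membered aromatic ring, gives it too. The step of no change at the digits printed from compound 1 to compound 3 (within the scatter) adds that methoxy and tert-butyl on that ring cannot be told apart here. No separate measurement explains these numbers. Still open, as far as these compounds go, is whether an amine or a carboxylic acid on that ring would match this, and whether a longer chain would match pentan-3-yl.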